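Swapping chloro for fluoro on a phenylpyrazole piperazine

This account rests on a few compounds, and the source may have more. Where it says the series, first, only, none or still open, it means among the compounds named here.

Four compounds share one core, a phenyl ring joined to a pyrazole that carries a piperazine, and differ only in the halogen on the phenyl ring and where it sits. Compound 1 `Clc1ccccc1-c1n[nH]cc1N1CCNCC1` carries chloro, and in an assay on isolated protein for binding affinity to 5-hydroxytryptamine receptor 6 (Homo sapiens) (a lower number here means a stronger inhibitor, a higher number a weaker inhibitor), compound 1 gives > 10000 nM, which is a limit of the assay rather than a number (the limit of > 10000 nM in this assay, at which 1 of the 3 values shown sits). Compound 3 `Fc1ccccc1-c1n[nH]cc1N1CCNCC1` carries fluoro at the same place; in this assay compound 3 gives 713 nM. The change from compound 1 to compound 3 is fluoro in place of chloro on an aromatic carbon, and it brought an at least 14-fold lower number from compound 1 to compound 3 (1.14 log units; beyond the scatter). Compound 2 `Clc1cccc(-c2n[nH]cc2N2CCNCC2)c1` has the same atoms as compound 1 joined differently; the difference between the two cores is not broken down here. In this assay compound 2 gives 109 nM, the lowest number among the measured compounds, with compound 3 next and beyond the scatter from it.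

Compound 4 `Fc1cccc(-c2n[nH]cc2N2CCNCC2)c1` is not yet measured in this assay. It differs from compound 2 by fluoro in place of chloro on an aromatic carbon. This is the same kind of change as from compound 1 to compound 3, but not the same: there the place was ortho to a large group, here it is meta to a large group. The value of compound 1 is a limit of the assay. The step of an at least 14-fold lower number from compound 1 to compound 3 (1.14 log units; beyond the scatter) thus gives only a direction, not a firm size. For compound 4 a step of a 1.8-fold higher number from compound 2 to compound 4 (0.26 log units; within the scatter) in this assay is expected, modest in either direction, since compound 2 already sits at 109 nM. Compound 4 is therefore estimated at 200 nM, with a range from 50 nM to 800 nM.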

Compound 4, inhibition constant: 162 nM
Compound 4: middle estimate off by 1.2-fold (0.09 log units), on the high side; measured number inside the range.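

Where the halogen is meta to a large group, fluoro in place of chloro brings a 1.5-fold higher number from compound 2 to compound 4 (0.17 log units; within the scatter), so the two halogens cannot be told apart at that place. Set beside the step on the other core, this shows that the same swap does not carry a single effect from one core to the other in this small series, and a large step on one core gave no sign of its size on the other: the same change on two cores in this assay, an at least 14-fold lower number (1.14 log units; beyond the scatter) from compound 1 to compound 3 and a 1.5-fold higher number (0.17 log units; within the scatter) from compound 2 to compound 4, at least 20-fold (1.31 log units) apart, beyond the scatter of two such steps It does not show the true size of the earlier step, nor why the two steps differ, and with a single pair on each core it gives no general rule, for the value of compound 1 is a limit of the assay and not a number: the limit of > 10000 nM in this assay, at which 1 of the 4 values shown sits.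

With only chloro and fluoro shown, it remains open whether the gap between the two cores would also appear with other groups at these places, such as bromo, methyl, methoxy or trifluoromethyl. Also open, on these data alone, is what a plain hydrogen at these places would give on either core, which would show how much either halogen contributes at all.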